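This account rests on a few compounds, and the source may have more. Where it says the series, first, only, none or still open, it means among the compounds named here.

Measured so far:
compound 1 `COc1ccc(SCc2ccc(/C=C/C(=O)Nc3ccccc3N)cc2)cc1OC`: 14.3%
compound 2 `COc1ccc(SCc2ccc(C(=O)Nc3ccccc3N)cc2)cc1`: 33.1%

In a functional assay on SMMC-7721 cells (Homo sapiens) for inhibition, read by CCK-8 assay, with a stated time of 72 h, tested at 2 uM (on this read-out lower numbers stand for less inhibition of growth and higher numbers for more inhibition of growth at the one concentration tested), compound 1 gives 14.3%, the lowest of the two numbers. Compound 2 gives 33.1%, higher by a gap beyond the usual scatter, but the two compounds differ in more than one place, so these values can only be set side by side.

Compound 3 `Cc1ccc(SCc2ccc(/C=C/C(=O)Nc3ccccc3N)cc2)cc1` differs from compound 1 in a single place: 4-methylphenyl in place of 3,4-dimethoxyphenyl on a sulfur. For the measured compounds named here, no measured pair shows a swap of this kind, so the size of the step in this assay has no precedent here, and nothing points in either direction; a step within the scatter is expected. Compound 3 is estimated at 15%, within a range from 4% to 32%. The expected step is a number 0.7 percentage points higher from compound 1 to compound 3 (within the scatter).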

Compound 3, percent growth inhibition at one concentration: 22%
Compound 3: middle estimate off by 7 percentage points, on the low side, and the stated range covers the measured number.
By their numbers in this assay, from the lowest: compounds 1 and 3 (each within the scatter of the next); then compound 2.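

In this assay, putting 4-methylphenyl in place of 3,4-dimethoxyphenyl on the sulfur gives a number 7.7 percentage points higher from compound 1 to compound 3 (within the scatter). The aromatic ring stays, while the hydrogen-bond acceptors counted on the leaving group go, and this swap produces no readable difference at the one concentration tested. Nothing available explains this result.

On these data alone, whether an amine or a carboxylic acid on this ring would shift growth inhibition remains open. So does the effect of a longer chain in place of the methyl.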